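Chloro for methoxy on the aromatic ring

A few compounds are considered here, and "the series" means these few. Any claim that something is new, unique, unknown or untested is made for them only; others in the source may bear on it.

Going by the values given here, in a functional assay on T47D cells (Homo sapiens) for cytotoxicity, read by MTT assay, with a stated time of 3 h (on this read-out lower numbers stand for stronger inhibition and higher numbers for weaker inhibition), compound 1 `Cc1ccc(-c2csc(NC(=O)CN3CCN(c4cc(=O)[nH]c5ccc(F)cc45)CC3)n2)cc1` gives 8410 nM and compound 2 `COc1ccc(-c2csc(NC(=O)CN3CCN(c4cc(=O)[nH]c5ccc(F)cc45)CC3)n2)cc1` gives 16900 nM in the same test, so compound 2 stands within the scatter of the only other number available. Compound 3 `O=C(CN1CCN(c2cc(=O)[nH]c3ccc(F)cc23)CC1)Nc1nc(-c2ccc(Cl)cc2)cs1` carries chloro in place of methoxy on an aromatic carbon and has not yet been measured. Among the compounds with values here, the one measured step, for methoxy in place of methyl, is a 2.0-fold higher number from compound 1 to compound 2 (0.30 log units; within the scatter) and offers no sign of a large change at this carbon. No step beyond the scatter is therefore expected in this assay for this swap. The expected step is a 1.5-fold lower number from compound 2 to compound 3 (0.19 log units; within the scatter) and lies within that scatter. Compound 3 is estimated at 11000 nM with 4500 nM to 27000 nM as its expected range.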

Compound 3, half-maximal inhibitory concentration: 2730 nM
Estimate against measurement, compound 3: 4.0-fold (0.61 log units) above, outside the stated range (below it).
By their numbers in this assay, from the lowest: compound 3; then compounds 1 and 2 (each within the scatter of the next).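

Chloro on this aromatic carbon, para to a large group, gives a 6.2-fold lower number from compound 2 to compound 3 (0.79 log units; beyond the scatter) and a 3.1-fold lower number from compound 1 to compound 3 (0.49 log units; beyond the scatter), so in this assay this position does respond to a change of group, which the step between compound 1 and compound 2 did not show. Compound 3 is the only one of the three set apart from both others beyond the scatter. Nothing available explains this difference. As far as these compounds go, whether fluoro, bromo or an amine on this carbon would give a lower or a higher number remains open. So does whether 4-chlorophenyl would have the same effect on a different core.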